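This account rests on a few compounds, and the source may have more. Where it says the series, first, only, none or still open, it means among the compounds named here.

Measured so far:
Compound 1 `O=C(Nc1cccc(S(=O)(=O)C2CCCC2)n1)c1ccc(NCCO)cc1N1CCC2(CC1)CC2`: > 399 mL.min-1.g-1
Compound 2 `CC(C)(C)NS(=O)(=O)c1cccc(NC(=O)c2ccc(NC(C)(C)CO)nc2N2CCC3(CC2)CC3)n1`: > 399 mL.min-1.g-1

In an ADME assay on microsomes from liver (Homo sapiens) for metabolic stability, read by LC-MS, with a stated time of 40 min, tested at 0.5 uM (on this read-out lower numbers stand for slow clearance and higher numbers for fast clearance), compound 1 gives > 399 mL.min-1.g-1, which is a limit of the assay and not a number. Compound 2 gives > 399 mL.min-1.g-1, likewise a limit. Both values rest at the limit of > 399 mL.min-1.g-1 in this assay, at which 2 of the 2 values shown sit, so compound 1 stands only at the edge of what the assay can report. Compound 3 `COc1ccc(C(=O)Nc2cccc(S(=O)(=O)C3CCCC3)n2)c(N2CCC3(CC2)CC3)c1` differs from compound 1 by methoxy in place of (2-hydroxyethyl)amino on an aromatic carbon. Within the data shown here, no measured pair shows a change of this kind, so the size and direction of the step are open; the step expected from compound 1 to compound 3 is an at least 1.3-fold lower number from compound 1 to compound 3 (0.12 log units; that floor lies within the scatter). Compound 3 is expected to give 300 mL.min-1.g-1, between 100 mL.min-1.g-1 and 600 mL.min-1.g-1.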

Compound 3, intrinsic clearance in microsomes: > 399 mL.min-1.g-1
Compound 3 ended at the assay's limit; the forecaster's own chance of this, stated with the estimate: 40%; middle value at least 1.3-fold (0.12 log units) from the limit.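

Among these compounds, no step from compound 1 to compound 3 can be read in this assay, since both results are limits of the assay and not numbers: the limit of > 399 mL.min-1.g-1 in this assay, at which 3 of the 3 values shown sit. From the compounds shown here alone, whether methoxy in place of (2-hydroxyethyl)amino changes clearance at all stays open.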